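Chloro to Fluoro on the Core: Cytotoxicity Outlook

The compounds below may be only part of what the source reports. "The series", "measured", "known", "first", "only" and "open" are said of these compounds alone.

Compound 1 `COc1cc2[nH]c(C)c(-c3ccc(Oc4ccc(F)cc4)cc3)c(=O)c2cc1Cl` gives in an ADME assay on HepG2 cells (Homo sapiens) for cytotoxicity, read by resazurin assay, with a stated time of 24 h (on this read-out higher numbers stand for weaker inhibition and lower numbers for stronger inhibition), a value of > 10000 nM, which is a limit of the assay and not a number.
Compound 2 `COc1cc2[nH]c(C)c(-c3ccc(Oc4ccc(Cl)cc4)cc3)c(=O)c2cc1Cl` gives in this assay a value of > 10000 nM, again a limit of the assay.
Compound 3 `Cc1[nH]c2ccc(Cl)cc2c(=O)c1-c1ccc(Oc2ccc(OC(F)(F)F)cc2)nc1` gives in this assay a value of > 10000 nM, also a limit of the assay.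

Compound 4 `Cc1[nH]c2ccc(F)cc2c(=O)c1-c1ccc(Oc2ccc(OC(F)(F)F)cc2)nc1` has not yet been measured in this assay. It differs from compound 3 by one change, (fluoro in place of chloro on an aromatic carbon). The same kind of change has already been made once among the measured compounds, from compound 2 to compound 1: fluoro in place of chloro on an aromatic carbon. That earlier step is a step that the two limits leave unreadable from compound 2 to compound 1; its size cannot be read because both compounds sit at the limit of > 10000 nM in this assay, at which 3 of the 3 values shown sit. The two changes are of the same kind but not the same: in the earlier pair the place is on a six-membered aromatic ring of carbon only, para to a large group, whereas in compound 3 the ring is part of a fused or bridged system of two rings, meta to a fused ring and para to a fused ring. How the core of compound 3 differs from the core of compound 2 is not broken down here.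

Since compound 3 already sits at the limit and the earlier step of this kind left no readable change, the step from compound 3 to compound 4 is expected to be about a step that the limit leaves unreadable from compound 3 to compound 4. Compound 4 is therefore expected to give roughly 20000 nM in this assay, most likely reported again only as a limit.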

Compound 4, half-maximal inhibitory concentration: > 10000 nM
Compound 4 was reported as a limit; the forecaster's own chance of this, stated with the estimate: 85%; the middle value is on the limit's open side.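

Compound 3 and compound 4 are both reported only as a limit of the assay, not as a number, so the step between them in this assay cannot be read. All the compounds shown end the same way: the limit of > 10000 nM in this assay, at which 4 of the 4 values shown sit.

The compounds shown leave open how far past this limit each one lies, and whether fluoro and chloro differ at all in this read-out.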